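Aryl changes on the ring nitrogen of the shared core

The source may report more compounds than this note shows. Statements on the series, on what has been measured and on what is new or still open speak of the compounds shown alone.

For the measured compounds named here, compound 2 `CNC(=O)c1cc(Oc2ccc(NC(=O)c3cc4cccnc4n(-c4ccc(F)cc4)c3=O)cc2)ccn1` gives 160 nM in a functional assay on HT-29 cells (Homo sapiens) for antiproliferative activity, read by MTT assay, with a stated time of 72 h (on this read-out lower numbers stand for stronger inhibition and higher numbers for weaker inhibition), and carries the lowest of the three numbers measured so far. Compound 1 `CNC(=O)c1cc(Oc2ccc(NC(=O)c3cc4cccnc4n(-c4ccccc4)c3=O)cc2)ccn1` gives 250 nM; the step of a 1.6-fold lower number from compound 1 to compound 2 (0.19 log units; within the scatter) lies within the scatter, so no order between compound 1 and compound 2 is claimed. Compound 3 `CNC(=O)c1cc(Oc2ccc(NC(=O)c3cc4cccnc4n(-c4ccc(OC)cc4)c3=O)cc2)ccn1` gives 920 nM; the steps of a 3.7-fold higher number from compound 1 to compound 3 (0.57 log units; beyond the scatter) and a 5.8-fold higher number from compound 2 to compound 3 (0.76 log units; beyond the scatter) both lie beyond the scatter.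

The next compound, compound 4 `CNC(=O)c1cc(Oc2ccc(NC(=O)c3cc4cccnc4n(-c4ccc(Br)cc4F)c3=O)cc2)ccn1`, differs from compound 2 by 4-bromo-2-fluorophenyl in place of 4-fluorophenyl on an aromatic nitrogen. Going by the values given here, no measured pair covers bromine in place of fluorine on this ring, nor a second fluorine on it. Among the compounds with values here, the steps that bear on the change are a 1.6-fold lower number from compound 1 to compound 2 (0.19 log units; within the scatter), which stays within the scatter, and a 3.7-fold higher number from compound 1 to compound 3 (0.57 log units; beyond the scatter) together with a 5.8-fold higher number from compound 2 to compound 3 (0.76 log units; beyond the scatter), which show a modest rise in the number with methoxy on the same ring. A small substituent change on this ring has so far stayed within the scatter; a larger one has raised the number. For compound 4 the expected step is therefore a 1.6-fold higher number from compound 2 to compound 4 (0.19 log units; within the scatter), a somewhat higher number or none beyond the scatter. Compound 4 is estimated at 250 nM, with a range from 100 nM to 650 nM.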

Compound 4, half-maximal inhibitory concentration: 1950 nM
Compound 4: middle estimate off by 7.8-fold (0.89 log units), on the low side; the measured number lies above the stated range.
By their numbers in this assay, from the lowest: compounds 2 and 1 (each within the scatter of the next); then compound 3; then compound 4.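

In this assay, 4-bromo-2-fluorophenyl on the aromatic nitrogen gives the largest step seen so far at this position, a 12-fold higher number from compound 2 to compound 4 (1.09 log units; beyond the scatter), and the rise holds against the unsubstituted aryl group, with a 7.8-fold higher number from compound 1 to compound 4 (0.89 log units; beyond the scatter). The step of a 2.1-fold higher number from compound 3 to compound 4 (0.33 log units; beyond the scatter) also carries this group past 4-methoxyphenyl, so the position spans a wider range of numbers than the first three compounds showed, and a halogen on this ring is not always a change within the scatter, as the fluoro step alone had left possible. Nothing measured here accounts for the rise.

As far as these compounds go, compound 4 differs from compound 2 by both a bromine and a second fluorine, so the shares of the two remain open, and 4-bromophenyl and 2-fluorophenyl on this nitrogen would separate them. Also open, from the compounds shown here alone, is how the number responds to an aryl ring carrying an amine or a carboxylic acid, or to a saturated group such as cyclohexyl in place of the aryl ring.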